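A Thiophene in Place of Methoxyphenyl at the Ketone

A few compounds are considered here, and "the series" means these few. Any claim that something is new, unique, unknown or untested is made for them only; others in the source may bear on it.

Of the compounds shown here, three have so far been tested in a functional assay for antagonist activity at metabotropic glutamate receptor 1 (Rattus norvegicus), read by scintillation counting and inositol phosphate accumulation; a higher number here means a weaker inhibitor, a lower number a stronger inhibitor. Compound 1 `COc1ccc(-c2cc(C)nc(-c3ccc(OC)c(Br)c3)c2)cc1Br` gives only a limit in this assay, > 40000 nM. Compound 3 `CCCCCCOc1ccc(C(=O)Oc2ccc(C3CCCCC3)cc2)cc1` likewise gives only a limit, > 40000 nM. Within the data shown here, compound 2 `COc1ccc(C(=O)/C=C/c2cc3cc(C)ccc3nc2Cl)cc1` is the one compound with a measured number, 20500 nM, which marks it as a weak inhibitor; the other two sit at the limit of > 40000 nM in this assay, at which 2 of the 3 values shown sit.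

Compound 4 `Cc1ccc2nc(Cl)c(/C=C/C(=O)c3cccs3)cc2c1` has not yet been measured. It differs from compound 2 in a single place: thiophen-2-yl in place of 4-methoxyphenyl on a carbonyl carbon. Among the measured compounds shown here, no pair of measured compounds shows the effect of this kind of exchange, so there is no measured step to lean on, and the two compounds that returned only limits say nothing about direction either. The expected step, a 1.2-fold higher number from compound 2 to compound 4 (0.09 log units; within the scatter), stays within the usual scatter, with a real chance that the assay returns only a limit rather than a number. Compound 4 is therefore estimated at 25000 nM in this assay, within a range from 8000 nM to 60000 nM.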

Compound 4, half-maximal inhibitory concentration: 740 nM
The estimate for compound 4 lay 34-fold (1.53 log units) above the measured number; measured number outside the range, below it.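

In this assay, the group on the carbonyl carbon proves to matter a great deal: thiophen-2-yl in place of 4-methoxyphenyl brings a 28-fold lower number from compound 2 to compound 4 (1.44 log units; beyond the scatter). Among these compounds, the earlier compounds offered no pair differing in one place, so this is the first sign that a single exchange at this position can move this series well beyond the scatter, and the direction is towards a stronger inhibitor. The exchange alters several things at once, replacing a six-membered aromatic ring of carbon only with a five-membered aromatic ring holding sulfur, and removing the methoxy group, and nothing shown here establishes which of these changes accounts for the result.

A plain phenyl group at the same carbonyl carbon would test the methoxy group apart from the ring, and furan-2-yl, with oxygen where thiophene has sulfur, would test the sulfur atom while keeping the five-membered ring. Going by these compounds, it also remains open whether the gain would survive a change elsewhere on the shared core, such as an amine in place of the chlorine.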